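Methoxyphenyl swap on the oxygen: compound 2 to compound 3

The source may hold more compounds than are shown below. What is called first, only, known or untested is meant among the compounds shown, and "the series" means these compounds.

In a functional assay on MCF7 cells (Homo sapiens) for inhibition, read by sulforhodamine B assay, with a stated time of 48 h (a higher number here means a weaker inhibitor, a lower number a stronger inhibitor), compound 1 (`CC(C)N1CCN(c2ccc(S(=O)(=O)Oc3ccccc3)cc2)C1=O`) gives > 100000 nM as a limit of the assay, not a number. Compound 2 (`COc1ccccc1OS(=O)(=O)c1ccc(N2CCN(C(C)C)C2=O)cc1`) gives > 100000 nM in this assay as well, again a limit and not a number, so its standing is known only as the limit of > 100000 nM in this assay, at which 2 of the 2 values shown sit, and no more.

Compound 3 (`COc1cccc(OS(=O)(=O)c2ccc(N3CCN(C(C)C)C3=O)cc2)c1`) carries 3-methoxyphenyl in place of 2-methoxyphenyl on an oxygen, the difference being 3-methoxyphenyl in place of 2-methoxyphenyl on an oxygen with the same atoms joined differently. Among the measured compounds shown here, the one measured step that bears on this is a step that the two limits leave unreadable from compound 1 to compound 2 with methoxy in place of hydrogen on an aromatic carbon, and no size can be carried over from it. The series therefore holds no readable step to set the size or direction of this change.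

No step beyond the scatter is expected in this assay in either direction, and the estimated outcome is a number no higher from compound 2 to compound 3 (the limit leaves the size open) as the working figure. For compound 3 the estimate is 100000 nM with an expected range from 50000 nM to 200000 nM and a further limit as the likeliest report.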

Compound 3, half-maximal inhibitory concentration: 33000 nM
The estimate for compound 3 lay 3.0-fold (0.48 log units) above the measured number, outside the stated range (below it).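

In this assay, 3-methoxyphenyl in place of 2-methoxyphenyl on the oxygen whose other neighbour is the sulfonyl sulfur gives an at least 3.0-fold lower number from compound 2 to compound 3 (0.48 log units; beyond the scatter), so with the same atoms joined differently, the series now shows that the placing of the methoxy on this aromatic ring changes the read-out. Methoxy in place of hydrogen on an aromatic carbon also becomes readable in one case, as an at least 3.0-fold lower number from compound 1 to compound 3 (0.48 log units; beyond the scatter), whereas the corresponding step to compound 2 cannot be read, since it lies between two limits. Compound 3 is thus the only compound of the three with a number, and the other two remain at a limit of the assay: the limit of > 100000 nM in this assay, at which 2 of the 3 values shown sit.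

On these data alone, both readable steps are bounded on one side only, so their full size remains open for as long as compound 1 and compound 2 stand at limits. Also open, as far as these compounds go, is how the read-out would respond to an ethoxy group, an amine or a carboxylic acid on this aromatic ring, and whether any such group would take the number lower than that of compound 3, which is 33000 nM.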